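Compound 2 to compound 3: (tert-butyl)carbonyl on oxygen

A few compounds are considered here, and "the series" means these few. Any claim that something is new, unique, unknown or untested is made for them only; others in the source may bear on it.

Within the data shown here, only two compounds have numbers so far in a functional assay on the whole organism for inhibition, with Rattus norvegicus as the target, read by paw edema, with stated times of 1 h and 3 h; on this read-out lower numbers stand for an effect already at smaller amounts and higher numbers for an effect only at larger amounts of compound. Compound 1 (`C/C(=N\NCC(=O)O)c1ccc(Cl)cc1`) gives 22 mg/kg and compound 2 (`C/C(=N\OCCO)c1ccc(Cl)cc1`) gives 29 mg/kg, which places compound 2 level with compound 1 within the scatter.

Compound 3 (`C/C(=N\OCCOC(=O)C(C)(C)C)c1ccc(Cl)cc1`) departs from compound 2 at one place: (tert-butyl)carbonyl in place of hydrogen on an oxygen on a saturated carbon. In words, (tert-butyl)carbonyl stands in place of hydrogen on an oxygen on a saturated carbon.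

One measured step is available, a 1.3-fold higher number from compound 1 to compound 2 (0.12 log units; within the scatter). It exchanges (carboxymethyl)amino for 2-hydroxyethoxy on a double-bonded nitrogen and stays within the scatter. Among the measured compounds shown here, it does not test the new change directly, and no measured pair carries (tert-butyl)carbonyl. For the measured compounds named here, with that step as the only guide, no shift beyond the scatter is expected in this assay, and the range is kept wide. The expected step is a 1.0-fold higher number from compound 2 to compound 3 (0.01 log units; within the scatter). The estimate for compound 3 is 30 mg/kg, with the measurement expected between 12 mg/kg and 75 mg/kg.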

Compound 3, dose for half-maximal effect: 38 mg/kg
Estimate against measurement, compound 3: 1.3-fold (0.10 log units) below, within the range that was stated.
By their numbers in this assay, from the lowest: compounds 1, 2 and 3 (each within the scatter of the next).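

In this assay, the step at an oxygen on a saturated carbon gives a 1.3-fold higher number from compound 2 to compound 3 (0.12 log units; within the scatter), so replacing a hydrogen atom with (tert-butyl)carbonyl, a group of 6 heavy atoms with no ring and no net charge, leaves the read-out level with that of the parent. Among these compounds, the earlier step concerned only the group on a double-bonded nitrogen, which makes this the first reading of a change at this oxygen, and here a large addition produces no shift beyond the scatter. No measurement on these compounds accounts for this result, and the step alone cannot say what lies behind it.

The compounds shown carry only hydrogen or (tert-butyl)carbonyl on this oxygen, and a single step at this place sets no trend and no limit on the size of group allowed. From the compounds shown here alone, how a smaller acetyl group, a methyl ether, an amine or a carboxylic acid on a longer chain at the same place would read in this assay remains open.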